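The source may hold more compounds than are shown below. What is called first, only, known or untested is meant among the compounds shown, and "the series" means these compounds.

Measured so far:
compound 1, `Cc1cccc(-c2cccc(NCc3cncn3Cc3ccccc3)c2)c1C`: > 1000 nM
compound 2, `c1ccc(-c2ccc(Cn3cncc3CNc3ccc(-c4onc5ccccc45)c(-c4ccccc4)c3)cc2)cc1`: > 10000 nM

In a toxicity assay on NIH3T3 cells (Mus musculus) for cytotoxicity, read by resazurin assay (on this read-out lower numbers stand for an effect already at smaller amounts and higher numbers for an effect only at larger amounts of compound), compound 1 gives > 1000 nM, which is a limit of the assay and not a number. Compound 1 therefore stands at the limit of > 1000 nM in this assay, at which 1 of the 2 values shown sits, and no effect on the cells was seen up to that point. In this assay compound 2 gives > 10000 nM, likewise a limit rather than a number. For the measured compounds named here, the two compounds differ in more than one place, so no step between them is counted; both merely show an absence of toxicity within the tested range.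

Compound 3, `CC(C)c1cccc(NCc2cncn2Cc2ccccc2)c1`, keeps the core of compound 1 and differs by isopropyl in place of 2,3-dimethylphenyl on an aromatic carbon. Going by the values given here, no measured step covers such a change. As both values shown are limits, the expected step is a step that the limit leaves unreadable from compound 1 to compound 3, none beyond the scatter. Compound 3 is expected to give 3000 nM in this assay, most likely again only a limit, within 1000 nM to 30000 nM.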

Compound 3, half-maximal effective concentration: > 1000 nM
Compound 3 gave a limit, no number; the forecaster's own chance of this, stated with the estimate: 80%; the middle value does not contradict the limit.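

In this assay compound 1 and compound 3 both give only limits, so no step can be read for isopropyl in place of 2,3-dimethylphenyl. The compounds shown leave open at what concentration, if any, compound 1 and compound 3 affect the cells.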